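Substituent swaps on the benzyl ring of the styryl sulfone series

This account rests on a few compounds, and the source may have more. Where it says the series, first, only, none or still open, it means among the compounds named here.

Compound 3 is `COc1cc(OC)c(/C=C/S(=O)(=O)Cc2ccc(O)cc2)c(OC)c1`. In a functional assay on H157 cells (Homo sapiens) for antiproliferative activity, read by trypan blue exclusion (on this read-out lower numbers stand for stronger inhibition and higher numbers for weaker inhibition), compound 3 gives 20000 nM. Compound 1 is `COc1cc(OC)c(/C=C/S(=O)(=O)Cc2ccc([N+](=O)[O-])cc2)c(OC)c1` and in this assay compound 1 gives 20000 nM. Compound 2 is `COc1cc(OC)c(/C=C/S(=O)(=O)Cc2ccc(C#N)cc2)c(OC)c1` and in this assay compound 2 gives 15000 nM. Thus compound 3 stands level with compound 1 and the pair sits together at the top of the three numbers; the steps of a 1.3-fold lower number from compound 1 to compound 2 (0.12 log units; within the scatter), no change at the digits printed from compound 1 to compound 3 (within the scatter) and a 1.3-fold higher number from compound 2 to compound 3 (0.12 log units; within the scatter) all stay within the scatter, so nitro, cyano and hydroxy on this aromatic carbon cannot be told apart on the present numbers.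

Compound 4 is `COc1ccc(CS(=O)(=O)/C=C/c2c(OC)cc(OC)cc2OC)cc1`. The change from compound 3 is methyl in place of hydrogen on an oxygen on an aromatic ring, that is, 4-hydroxyphenyl to 4-methoxyphenyl. Among the compounds with values here, no measured step covers a hydroxy-to-methoxy exchange; the three steps known here each exchange one substituent on this aromatic carbon for another and none moves beyond the scatter. On that basis no step beyond the scatter is expected for compound 4 in this assay, with no change at the digits printed from compound 3 to compound 4 (within the scatter) as the expected step. Compound 4 is therefore estimated at 20000 nM, with a range from 8000 nM to 50000 nM.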

Compound 4, half-maximal inhibitory concentration: 30 nM
Compound 4: middle estimate off by 670-fold (2.82 log units), on the high side, outside the stated range (below it).
By their numbers in this assay, from the lowest: compound 4; then compounds 2, 1 and 3 (each within the scatter of the next).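

In this assay this aromatic carbon proves far from indifferent to its substituent: methoxy gives a 670-fold lower number from compound 3 to compound 4 (2.82 log units; beyond the scatter) and also a 500-fold lower number from compound 2 to compound 4 (2.70 log units; beyond the scatter) and a 670-fold lower number from compound 1 to compound 4 (2.82 log units; beyond the scatter) while nitro, cyano and hydroxy stay within the scatter of one another. Within the data shown here, the first of these steps adds only a methyl on the oxygen, a single heavy atom, so the flat picture from the earlier compounds holds for those three groups and not for the position as a whole. No data on hand account for this step.

From the compounds shown here alone, whether the gain is confined to methoxy or extends to a longer chain on the oxygen, such as ethoxy, remains open. Also open, going by these compounds, is how an amine or a plain methyl on this aromatic carbon would compare.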